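From acetyl to hydroxymethyl on an unsaturated chain

This account rests on a few compounds, and the source may have more. Where it says the series, first, only, none or still open, it means among the compounds named here.

Measured in a functional assay on HeLa cells (Homo sapiens) for inhibition (on this read-out lower numbers stand for stronger inhibition and higher numbers for weaker inhibition), so far:
- compound 1 `Cc1cn(/C=C/C=O)c(=O)[nH]c1=O` gives 25000 nM
- compound 2 `Cc1cn(/C=C/C#N)c(=O)[nH]c1=O` gives > 100000 nM as a limit
- compound 3 `CC(=O)/C=C/n1cc(C)c(=O)[nH]c1=O` gives > 100000 nM as a limit

Compound 3 stands at > 100000 nM in this assay as a limit, not a number. Compound 3 therefore has no exact place on the scale and sits at the limit of > 100000 nM in this assay, at which 2 of the 3 values shown sit, and nothing finer can be said.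

The change from compound 3 to compound 4 `Cc1cn(/C=C/CO)c(=O)[nH]c1=O` is hydroxymethyl in place of acetyl on a double-bonded chain carbon bound to a double-bonded chain carbon and compound 4 is still unmeasured.

Among the measured compounds shown here, no measured step makes this exact swap. The nearest evidence starts from the formyl group of compound 1, where an at least 4.0-fold higher number from compound 1 to compound 2 (0.60 log units; beyond the scatter) and an at least 4.0-fold higher number from compound 1 to compound 3 (0.60 log units; beyond the scatter) are both at least modest and beyond the scatter. There is also a step that the two limits leave unreadable from compound 2 to compound 3 and so nitrile and acetyl cannot be ranked.

Compound 4 lacks formyl too, so no step beyond the scatter is expected in this assay and another limit is likely. The estimated outcome is a step that the limit leaves unreadable from compound 3 to compound 4 and it remains an expectation. For the measured compounds named here, for compound 4 the estimate is 120000 nM with an expected range from 40000 nM to 300000 nM and no measurement yet.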

Compound 4, half-maximal inhibitory concentration: > 100000 nM
Compound 4 gave a limit, no number; the forecaster's own chance of this, stated with the estimate: 75%; the middle value is on the limit's open side.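

In this assay, among the compounds shown here, formyl now stands apart from a third replacement on this double-bonded chain carbon, with an at least 4.0-fold higher number from compound 1 to compound 4 (0.60 log units; beyond the scatter) as the one readable step, so nitrile, acetyl and hydroxymethyl all give weaker inhibition than formyl here. Hydroxymethyl brings a hydrogen-bond donor that acetyl lacks, yet this swap gives no readable gain: the steps from compound 3 and from compound 2 to compound 4 join two limits and cannot be read, so these three groups stay unranked. Compound 4 gives a limit, not a number, and it joins the others there: the limit of > 100000 nM in this assay, at which 3 of the 4 values shown sit.

The compounds shown leave open whether formyl alone gives a readable number at this place, or whether an amine or a carboxylic acid there would too. Nor do they tell how far compound 2, compound 3 and compound 4 lie from one another on the scale.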